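Xanthine-pyrazole series: benzyl substituent change on the pyrazole nitrogen

The source may report more compounds than this note shows. Statements on the series, on what has been measured and on what is new or still open speak of the compounds shown alone.

Measured compounds:
compound 1, `CCCn1c(=O)c2nc(-c3cnn(Cc4ccc(F)cc4F)c3)[nH]c2n(CCC)c1=O`, "not determined" (no result reported)
compound 2, `CCCn1c(=O)c2nc(-c3cnn(Cc4cc(C(F)(F)F)ccc4Cl)c3)[nH]c2n(CCC)c1=O`, 1200 nM
compound 3, `CCCn1c(=O)c2nc(-c3cnn(Cc4ccc(OC)c(C(F)(F)F)c4)c3)[nH]c2n(CCC)c1=O`, "not determined" (no result reported)

Going by the values given here, only one number stands for the series. In an assay on CHO cells for displacement of a labelled ligand from adenosine receptor A1 (Homo sapiens) (a lower number here means a stronger inhibitor, a higher number a weaker inhibitor), compound 2 gives 1200 nM. In this assay, among the compounds with values here, compound 1 gives "not determined" (no result reported) and compound 3 gives "not determined" (no result reported), so no step between measured compounds can be stated and nothing is known about how the benzyl group's substitution pattern moves the numbers.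

Compound 4, `CCCn1c(=O)c2nc(-c3cnn(Cc4cccc(Cl)c4)c3)[nH]c2n(CCC)c1=O`, is not yet measured. It differs from compound 2 in one place: 3-chlorophenyl in place of 2-chloro-5-(trifluoromethyl)phenyl on a saturated chain carbon bound to an aromatic nitrogen. The change removes the trifluoromethyl group and moves the single chlorine to a different position on the phenyl ring, in the words of the difference given above. Within the data shown here, with no step on record to lean on, the expectation for compound 4 is a change from compound 2 of a 1.2-fold lower number from compound 2 to compound 4 (0.08 log units; within the scatter) in this assay, which is within the usual scatter rather than a clear shift in either direction. Compound 4 is therefore estimated at 1000 nM, with a range from 300 nM to 4000 nM.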

Compound 4, inhibition constant: 31 nM
Estimate against measurement, compound 4: 32-fold (1.51 log units) above, and the stated range ends above it.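

The group on a saturated chain carbon bound to an aromatic nitrogen now has a first measured step: in this assay, 3-chlorophenyl in place of 2-chloro-5-(trifluoromethyl)phenyl gives a 39-fold lower number from compound 2 to compound 4 (1.59 log units; beyond the scatter), so this position responds strongly to the phenyl substituents. The change removes the trifluoromethyl group and moves the chlorine at once, going from 11 heavy atoms to 7, so the step cannot be divided between those two changes. Nothing on hand explains the size of this step.

Steps involving compound 1 and compound 3 cannot be read, as neither has a number. Open, on these data alone, is how much of the step belongs to each change, which 3-(trifluoromethyl)phenyl or an unsubstituted phenyl on the same carbon could help to separate.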